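Substance-P receptor series: amide side chain variation

This account rests on a few compounds, and the source may have more. Where it says the series, first, only, none or still open, it means among the compounds named here.

Measured compounds:
compound 1 `CCCCCN(CCCCC)C(=O)N1CCN(C(=O)N(c2ccccc2)c2ccccc2)[C@H](C(=O)NCCNC(C)=O)C1` — 140 nM
compound 2 `CCCCCN(CCCCC)C(=O)N1CCN(C(=O)N(c2ccccc2)c2ccccc2)[C@H](C(=O)N(C)CCN(C)Cc2ccccc2)C1` — 290 nM
compound 3 `CCCCCN(CCCCC)C(=O)N1CCN(C(=O)N(c2ccccc2)c2ccccc2)[C@@H](C(=O)O)C1` — 3000 nM

All three share the same core and differ only in what hangs from the carboxyl carbon. In an assay on CHO cells for binding affinity to Substance-P receptor (Homo sapiens) (a lower number here means a stronger inhibitor, a higher number a weaker inhibitor), compound 1 gives 140 nM, the lowest of the three numbers. Compound 2, with a tertiary amide carrying a benzylated methylamino chain, gives 290 nM; the gap from compound 1 to compound 2 lies beyond the scatter, though not by much. Compound 3, the free acid, gives 3000 nM, the highest number of the set and far beyond the scatter from compound 1.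

Compound 4 `CCCCCN(CCCCC)C(=O)N1CCN(C(=O)N(c2ccccc2)c2ccccc2)[C@H](C(=O)NCCN(C)Cc2ccccc2OC)C1` has not yet been measured. It keeps the secondary amide of compound 1 and changes the chain end: (2-methoxybenzyl)(methyl)amino in place of acetamido on a saturated chain carbon, two bonds along the chain from an amide-type nitrogen. Within the data shown here, the new chain end resembles the one in compound 2 but with a methoxy on the benzyl ring and without the methyl on the amide nitrogen. Compound 2 shows that such a benzylated amino chain still gives a number in the same region as compound 1; compound 3 shows that only the loss of the whole amide costs much. The step from compound 1 to compound 4 is therefore expected to be small, in either direction or within the scatter, a 1.1-fold higher number from compound 1 to compound 4 (0.03 log units; within the scatter). For compound 4 the estimate in this assay is 150 nM, with a range from 50 nM to 450 nM.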

Compound 4, half-maximal inhibitory concentration: 9 nM
Compound 4: middle estimate off by 17-fold (1.22 log units), on the high side; measured number below the stated range.
By their numbers in this assay, from the lowest: compound 4; then compound 1; then compound 2; then compound 3.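

In this assay, (2-methoxybenzyl)(methyl)amino in place of acetamido on a saturated chain carbon, two bonds along the chain from an amide-type nitrogen, gives a 16-fold lower number from compound 1 to compound 4 (1.19 log units; beyond the scatter) and so counts as a large change at this position. The earlier compounds differ from one another in more than one place, so this is the only single-change reading of the chain end among the compounds shown, and it shows that the group held there can move the number well beyond the scatter. No measurement at hand accounts for the size of this step.

The entering group brings a benzyl ring, a methoxy and a tertiary amine together, so the compounds shown leave open which of these parts carries the step; a plain benzyl(methyl)amino end on the same secondary amide, or a hydroxy or chlorine in place of the methoxy, would separate them. Also open, from the compounds shown here alone, are the effect of a methyl on the amide nitrogen with this chain end held fixed and the effect of a longer chain between the amide nitrogen and the amine.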